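The source may report more compounds than this note shows. Statements on the series, on what has been measured and on what is new or still open speak of the compounds shown alone.

Of the compounds shown here, three sharing one core have been measured in a physicochemical assay for solubility; a higher number here means a more soluble compound, a lower number a less soluble compound: compound 1 (`O=C(c1ccccn1)N1CCC(NS(=O)(=O)c2cc(S(=O)(=O)c3ccccc3)ccc2C(F)(F)F)CC1`) gives 100000 nM, compound 2 (`O=C(O)c1ccc(S(=O)(=O)N2CCC(NS(=O)(=O)c3cc(S(=O)(=O)c4ccccc4)ccc3C(F)(F)F)CC2)cc1`) gives 12500 nM and compound 3 (`O=C(O)c1ccc(N2CCC(NS(=O)(=O)c3cc(S(=O)(=O)c4ccccc4)ccc3C(F)(F)F)CC2)cc1`) gives 25000 nM. Compound 3 is the middle number of the three, but the data do not separate it from its nearest neighbour: a 2.0-fold higher number from compound 2 to compound 3 (0.30 log units; within the scatter). The gap to the top value is wider: a 4.0-fold lower number from compound 1 to compound 3 (0.60 log units; beyond the scatter), and likewise an 8.0-fold lower number from compound 1 to compound 2 (0.90 log units; beyond the scatter).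

Compound 4 (`O=C(O)CCCC(=O)N1CCC(NS(=O)(=O)c2cc(S(=O)(=O)c3ccccc3)ccc2C(F)(F)F)CC1`) has (3-carboxypropyl)carbonyl in place of 4-carboxyphenyl on an amine nitrogen in a ring. It keeps the carboxy group of compound 3 but, like compound 1 at 100000 nM, has a carbonyl on that nitrogen, so part of that gap is expected to return. The expected step is upward and small, possibly within the scatter: a 1.8-fold higher number from compound 3 to compound 4 (0.26 log units; within the scatter). The estimate for compound 4 is 45000 nM, with an expected range of 18000 nM to 100000 nM.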

Compound 4, solubility: 50000 nM
The estimate for compound 4 lay 1.1-fold (0.05 log units) below the measured number; low and high end bracket the measured number.
By their numbers in this assay, from the lowest: compounds 2, 3, 4 and 1 (each within the scatter of the next, the first and the last beyond it).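

In this assay, (3-carboxypropyl)carbonyl on the amine nitrogen cannot be told from 4-carboxyphenyl (a 2.0-fold higher number from compound 3 to compound 4 (0.30 log units; within the scatter)), nor 3-carboxypropyl on the carbonyl carbon from pyridin-2-yl (a 2.0-fold lower number from compound 1 to compound 4 (0.30 log units; within the scatter)). Among the compounds shown here, it does separate from (4-carboxyphenyl)sulfonyl (a 4.0-fold higher number from compound 2 to compound 4 (0.60 log units; beyond the scatter)), the first pair of carboxy-bearing compounds to lie beyond the scatter, so a carboxy group alone does not set the number at this position. No supporting data bear on the reason for these steps.

Still open, from the compounds shown here alone, is what the carboxylic acid of the chain contributes: the same carbonyl-linked chain ending in a primary amide or an amine would address that.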